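The source may report more compounds than this note shows. Statements on the series, on what has been measured and on what is new or still open speak of the compounds shown alone.

Measured in a functional assay on PC-3 cells (Homo sapiens) for inhibition, read by MTT assay, with a stated time of 72 h; a lower number here means a stronger inhibitor, a higher number a weaker inhibitor:
compound 1 `C=CC(=O)Nc1cccc(NC(=O)CSc2nc(Nc3cccc(Cl)c3)c3ccccc3n2)c1` gives 12300 nM
compound 2 `C=CC(=O)Nc1cccc(NC(=O)CSc2nc(Nc3ccc(F)cc3)c3ccccc3n2)c1` gives 8240 nM

Among the compounds with values here, compound 2 stands close to compound 1 in this assay; the only step so far, a 1.5-fold lower number from compound 1 to compound 2 (0.17 log units; within the scatter), lies within the scatter, so no order between the two can be claimed. Compound 3 `C=CC(=O)Nc1cccc(NC(=O)CSc2nc(Nc3ccc(CC)cc3)c3ccccc3n2)c1` differs from compound 2 by ethyl in place of fluoro on an aromatic carbon, para to a large group. Within the data shown here, no measured step makes this change; the one step at hand, a 1.5-fold lower number from compound 1 to compound 2 (0.17 log units; within the scatter), swapped one halogen-bearing ring for another and stayed within the scatter. The expectation for compound 3 in this assay is therefore no step beyond the scatter, a 1.0-fold lower number from compound 2 to compound 3 (0.01 log units; within the scatter). Compound 3 is estimated at 8000 nM, with a range from 3000 nM to 20000 nM.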

Compound 3, half-maximal inhibitory concentration: 24300 nM
The estimate for compound 3 lay 3.0-fold (0.48 log units) below the measured number, and the stated range ends below it.
By their numbers in this assay, from the lowest: compounds 2, 1 and 3 (each within the scatter of the next, the first and the last beyond it).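

In this assay, within the data shown here, a 2.9-fold higher number from compound 2 to compound 3 (0.47 log units; beyond the scatter) is the first step to clear the scatter, so what sits on this aromatic carbon can change the number, and here ethyl in place of fluoro gives a weaker inhibitor. Against the other ring, a 2.0-fold higher number from compound 1 to compound 3 (0.30 log units; within the scatter) does not set compound 3 apart from compound 1. No data at hand explain the step between compound 2 and compound 3.

On these data alone, whether an amine, a methoxy group or a longer chain at this place would shift the number further remains open. Two groups at this place also cannot show whether any trend runs through them.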